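The compounds below may be only part of what the source reports. "The series", "measured", "known", "first", "only" and "open" are said of these compounds alone.

Compound 1 `CN1C/C(=C\c2cccs2)C(O)/C(=C/c2cccs2)C1`: > 100000 nM
Compound 2 `CN1C/C(=C\c2cccs2)C2=NN(C)C(c3cccs3)C2C1`: > 100000 nM
Compound 3 `CN1C/C(=C\c2cccs2)C2=NN(c3ccccc3)C(c3cccs3)C2C1`: not yet measured

In a functional assay on cells (Panel CNS (Carcinoma cell lines), Homo sapiens) for inhibition (a higher number here means a weaker inhibitor of growth, a lower number a stronger inhibitor of growth), compound 2 gives > 100000 nM, which is a limit of the assay and not a number. Compound 1 gives > 100000 nM, also a limit. So compound 2 has no exact value to start from, and no measured step shows what a change in structure does here.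

Compound 3 carries phenyl in place of methyl on an amine nitrogen in a ring. A modest move towards stronger growth inhibition is expected, though the result could well stay at the limit, and the expected change is an at least 2.0-fold lower number from compound 2 to compound 3 (0.30 log units; that floor lies within the scatter). The estimated value for compound 3 is 50000 nM, with an expected range from 15000 nM to 100000 nM.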

Compound 3, concentration for total growth inhibition: > 100000 nM
Compound 3 ended at the assay's limit (the forecaster's own chance of this, stated with the estimate: 55%); middle value at least 2.0-fold (0.30 log units) from the limit.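

Compound 2 and compound 3 both sit at a limit of this assay, so the step from methyl to phenyl cannot be read: the limit of > 100000 nM in this assay, at which 3 of the 3 values shown sit.

The compounds shown leave open which change to the shared core, if any, would give an exact value.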